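A few compounds are considered here, and "the series" means these few. Any claim that something is new, unique, unknown or untested is made for them only; others in the source may bear on it.

Measured so far:
compound 1 `CCCC(C)ON1C(=O)c2ccccc2C1=O` — 0%
compound 2 `CCCCCCC(ON1C(=O)c2ccccc2C1=O)C(=O)OCC` — 0%

In a functional assay on the whole organism for inhibition, with Lepidium sativum as the target, tested at 1 ppm (on this read-out lower numbers stand for less inhibition of growth and higher numbers for more inhibition of growth at the one concentration tested), compound 1 gives 0% and compound 2 gives 0%. Compound 1 thus stands level with compound 2 at the digits shown; no step between the two is worked out, and the values show only that neither compound inhibits growth at the single concentration tested. Among the measured compounds shown here, with both points at the floor of the read-out, the series so far gives no spread at all.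

Compound 3 `CCCCOC(=O)C(C)ON1C(=O)c2ccccc2C1=O` differs from compound 1 in one place: butoxycarbonyl in place of propyl on a saturated chain carbon bound to an oxygen on an unsaturated carbon and a saturated chain carbon. For the measured compounds named here, no step between measured compounds is available, so the expectation rests on the two values alone. Compound 2 carries a long chain and an ester in place of the short propyl and still gives 0%, which gives no sign that added bulk or a carbonyl at this position shifts the read-out. The step of a number 2 percentage points higher from compound 1 to compound 3 (within the scatter) is therefore expected to be none beyond the scatter, in neither direction. Compound 3 is estimated at 2%, with a range from 0% to 12%.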

Compound 3, percent growth inhibition at one concentration: 59%
Compound 3: middle estimate off by 57 percentage points, on the low side; measured number outside the range, above it.
By their numbers in this assay, from the lowest: compounds 1 and 2 (each within the scatter of the next); then compound 3.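

In this assay, butoxycarbonyl in place of propyl on a saturated chain carbon bound to an oxygen on an unsaturated carbon and a saturated chain carbon gives a number 59 percentage points higher from compound 1 to compound 3 (beyond the scatter). This position is therefore not silent: a change in this one place produces the first spread in the series, so the shared core does not by itself hold the read-out at the floor. Nothing at hand bears on the reason for this step.

Which part of the butoxycarbonyl group goes with the step stays open, whether the carbonyl, the chain oxygen or the butyl chain, and a carboxylic acid, a methoxycarbonyl group or a butyl amide on the same carbon would help to separate these. Also open, going by these compounds, is how compound 3 behaves across a range of concentrations, as the single concentration of this read-out gives one point per compound and no curve.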